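The source may hold more compounds than are shown below. What is called first, only, known or untested is meant among the compounds shown, and "the series" means these compounds.

Compound 1 `CCCOC(=O)C1=C(C)NC(=O)NC1c1ccoc1` in an assay on membranes from HeLa cells for displacement of a labelled ligand from adenosine receptor A3 (Homo sapiens), read by scintillation counting, with a stated time of 180 min, tested at 1 uM (a higher number here means more inhibition at the concentration tested (going by the name of the read-out), a lower number less inhibition), gives 11%.
Compound 2 `CC1=C(C(=O)OCc2ccccc2)C(c2cccs2)NC(=O)N1` gives 8%.
Compound 3 `CCCOC(=O)C1=C(C)NC(=O)NC1c1ccsc1` gives 6%.

Compound 3 has the lowest of the three numbers, but its gap to compound 2, the nearest, and its gap to compound 1, the furthest, both lie within the scatter, so no order among the three can be claimed. Within the data shown here, the only measured step that changes one place, a number 5 percentage points lower from compound 1 to compound 3 (within the scatter), is likewise within the scatter.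

Compound 4 `CC1=C(C(=O)OCc2ccccc2)C(c2ccsc2)NC(=O)N1` is to be measured in this assay. It differs from compound 3 by phenyl in place of ethyl on a saturated chain carbon bound to an oxygen next to a carbonyl group; the same difference, cut one bond further out, reads propyl to benzyl. Among the measured compounds shown here, no measured step isolates this exchange: compound 2 carries the benzyl group but differs from compound 4 in a second place as well, and the values of compound 2 and compound 3 are within the scatter of each other. Nothing in the data therefore points to a step beyond the scatter, and the step of a number 2 percentage points higher from compound 3 to compound 4 (within the scatter) is expected to be small. Compound 4 is estimated at 8%, with a range from 0% to 18%.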

Compound 4, a percentage reported as inhibition, at one concentration (the size of the read-out at that concentration, not a potency): 25%
The estimate for compound 4 lay 17 percentage points below the measured number, and the stated range ends below it.
By their numbers in this assay, from the lowest: compounds 3, 2 and 1 (each within the scatter of the next); then compound 4.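

In this assay phenyl in place of ethyl on a saturated chain carbon bound to an oxygen next to a carbonyl group gives a number 19 percentage points higher from compound 3 to compound 4 (beyond the scatter) and so shows that this place can move the read-out, which no earlier comparison had shown. With the benzyl group in place, thiophen-3-yl in place of thiophen-2-yl on a saturated ring carbon gives a number 17 percentage points higher from compound 2 to compound 4 (beyond the scatter) and so shows that the ring carbon substituent also matters in this setting. The data offer no explanation for either step.

From the compounds shown here alone, whether propyl to benzyl has the same effect with thiophen-2-yl or furan-3-yl on the ring remains open. So does how a phenethyl group, or a benzyl group carrying a methoxy group or an amine, would read at this place.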